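Chain truncation on the benzylated core: compound 2 to compound 4

The source may report more compounds than this note shows. Statements on the series, on what has been measured and on what is new or still open speak of the compounds shown alone.

Compound 1 `CCCCCCCCCCCCCCCCCC/N=c1\nc(N)c2nc[nH]c2c(N)n1` gives 2610 nM in a functional assay on PC-3 cells (Homo sapiens) for antiproliferative activity, read by WST assay, with a stated time of 72 h; a higher number here means a weaker inhibitor, a lower number a stronger inhibitor. Compound 2 `CCCCCCCCCCCCCCCCCC/N=c1\nc(N)c2ncn(Cc3ccccc3)c2c(N)n1` gives 5450 nM in this assay; the step of a 2.1-fold higher number from compound 1 to compound 2 (0.32 log units; beyond the scatter) is the benzyl on the aromatic nitrogen. Compound 3 `CCCCCCCCCCCCCC/N=c1\nc(N)c2ncn(Cc3ccccc3)c2c(N)n1` gives 4200 nM in this assay. Among the three measured compounds, compound 2 has the highest number; the gap to compound 3 lies within the scatter, while the gap to compound 1 lies beyond it.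

Compound 4 `CCCCCCCC/N=c1\nc(N)c2ncn(Cc3ccccc3)c2c(N)n1` differs from compound 2 by hydrogen in place of decyl on a saturated chain carbon, eight bonds along the chain from a double-bonded nitrogen. Within the data shown here, the only measured step that bears on this change is the chain shortening a 1.3-fold lower number from compound 2 to compound 3 (0.11 log units; within the scatter), which lies within the scatter. Among the measured compounds shown here, the cut to compound 4 removes a far longer piece of the chain, and no measured pair covers a truncation of that size, so the direction rests on a single small step. A number on the weaker side is expected, without confidence that it will clear the scatter. Compound 4 is therefore estimated at 7500 nM in this assay, within 3000 nM to 20000 nM. That estimate corresponds to an expected step of a 1.4-fold higher number from compound 2 to compound 4 (0.14 log units; within the scatter).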

Compound 4, half-maximal inhibitory concentration: 5930 nM
Beside the measured number, compound 4's estimate is 1.3-fold (0.10 log units) above it; measured number inside the range.
By their numbers in this assay, from the lowest: compounds 1, 3, 2 and 4 (each within the scatter of the next, the first and the last beyond it).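

On the benzylated core, in this assay, hydrogen in place of decyl on a saturated chain carbon, eight bonds along the chain from a double-bonded nitrogen, gives a 1.1-fold higher number from compound 2 to compound 4 (0.04 log units; within the scatter), and hydrogen in place of hexyl at that same place gives a 1.4-fold higher number from compound 3 to compound 4 (0.15 log units; within the scatter). Both steps lie within the scatter, so among compounds 2, 3 and 4 a cut as large as the loss of decyl leaves no readable difference, which the smaller step from compound 2 to compound 3 alone could not show. Nothing measured here accounts for this.

Going by these compounds, whether a chain longer than that of compound 2, or an amine or a carboxylic acid on the chain, would separate from these numbers remains open. Also open, on these data alone, is how the shorter chains read with hydrogen in place of benzyl on the aromatic nitrogen.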